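Compound 2 without its hydroxymethyl: working notes

The source may report more compounds than this note shows. Statements on the series, on what has been measured and on what is new or still open speak of the compounds shown alone.

Of the compounds shown here, two have been measured so far in a functional assay on NIH3T3 cells (Mus musculus) for inhibition; on this read-out higher numbers stand for weaker inhibition and lower numbers for stronger inhibition. Compound 1 `CCCCCCCCCCCCCCCCCCOC[C@H](COP(=O)(O)O[C@H]1[C@@H](O)[C@@H](O)[C@H](O)C[C@H]1O)OC` gives 4500 nM, and compound 2 `CCCCCCCCCCCCCCCCCCOC[C@H](COP(=O)(O)O[C@@H]1[C@H](O)[C@@H](CO)[C@@H](O)[C@H](O)[C@@H]1O)n1ccnc1` gives 8200 nM. Within the data shown here, these two values lie within the usual scatter of each other, so compound 2 stands level with the only other measured compound.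

Compound 3 `CCCCCCCCCCCCCCCCCCOC[C@H](COP(=O)(O)O[C@H]1[C@@H](O)[C@@H](O)[C@H](O)C[C@H]1O)n1ccnc1` is still unmeasured. It carries hydrogen in place of hydroxymethyl on a saturated ring carbon, so that 2,3,4,6-tetrahydroxy-5-(hydroxymethyl)cyclohexyl becomes 2,3,4,6-tetrahydroxycyclohexyl. Among the measured compounds shown here, no pair of measured compounds shows this change alone, and the data give no direct size for it.

The only spread available is that between compound 1 at 4500 nM and compound 2 at 8200 nM, which stays within the scatter. In this assay, on these data alone, no shift beyond the scatter is therefore expected, and the direction remains open, with a slight lean toward a lower number. The estimated 1.5-fold lower number from compound 2 to compound 3 (0.17 log units; within the scatter) is small. For compound 3 the expected value is 5500 nM, with an estimated range of 2200 nM to 14000 nM.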

Compound 3, half-maximal inhibitory concentration: 6500 nM
For compound 3 the middle estimate is 1.2-fold (0.07 log units) below the measured one, within the range that was stated.
By their numbers in this assay, from the lowest: compounds 1, 3 and 2 (each within the scatter of the next).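

In this assay the replacement of 2,3,4,6-tetrahydroxy-5-(hydroxymethyl)cyclohexyl by 2,3,4,6-tetrahydroxycyclohexyl now has a direct size (a 1.3-fold lower number from compound 2 to compound 3 (0.10 log units; within the scatter)), and that step lies within the scatter, so compound 2 and compound 3 stand level and hydroxymethyl on this saturated ring carbon shows no effect on the number beyond the scatter. The second step isolates a different place, 1H-imidazol-1-yl in place of methoxy on a saturated chain carbon bound to two saturated chain carbons (a 1.4-fold higher number from compound 1 to compound 3 (0.16 log units; within the scatter)), and it too lies within the scatter, so neither single change separates its pair of compounds on this read-out. Nothing available on these compounds explains why either step is this small.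

The compounds shown leave open whether an amine or a carboxylic acid on the same saturated ring carbon would give a step beyond the scatter, since hydrogen and hydroxymethyl are the only two groups compared there. On these data alone, on the saturated chain carbon the same question stands for a dimethylamino group in place of 1H-imidazol-1-yl or methoxy, and a longer chain in place of the present one remains equally open.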